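Fluoro to hydroxymethyl on compound 1

The source may hold more compounds than are shown below. What is called first, only, known or untested is meant among the compounds shown, and "the series" means these compounds.

For the measured compounds named here, in an ADME assay on microsomes from liver (Homo sapiens) for metabolic stability (on this read-out lower numbers stand for slow clearance and higher numbers for fast clearance), compound 1 `O=C(Nc1ccnnc1)c1cc(N2CCC(F)CC2)ccc1OCc1ccccc1` gives 5.5 mL.min-1.g-1, the higher of the two numbers so far, and compound 2 `O=C(Nc1ccnnc1)c1cc(N2CCNCC2)ccc1OCc1ccccc1` gives 0.4 mL.min-1.g-1. Compound 3 `O=C(Nc1ccnnc1)c1cc(N2CCC(CO)CC2)ccc1OCc1ccccc1` carries hydroxymethyl in place of fluoro on a saturated ring carbon. Going by the values given here, one measured step bears on this change: a 14-fold lower number from compound 1 to compound 2 (1.14 log units; beyond the scatter), with piperazin-1-yl in place of 4-fluoropiperidin-1-yl. That step replaces the whole group, so it is only a loose guide. A smaller move towards a lower number is expected in this assay, estimated as a 2.2-fold lower number from compound 1 to compound 3 (0.34 log units; beyond the scatter). For compound 3 the estimated value is 2.5 mL.min-1.g-1, with an expected range of 1 mL.min-1.g-1 to 6 mL.min-1.g-1.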

Compound 3, intrinsic clearance in microsomes: 1 mL.min-1.g-1
The estimate for compound 3 lay 2.5-fold (0.40 log units) above the measured number, and the stated range covers the measured number.
By their numbers in this assay, from the lowest: compound 2; then compound 3; then compound 1.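

In this assay, changing only the group on the saturated ring carbon gives a 5.5-fold lower number from compound 1 to compound 3 (0.74 log units; beyond the scatter) while the rest of compound 1 stays in place, so this single position alone moves the read-out beyond the scatter. The step of a 2.5-fold higher number from compound 2 to compound 3 (0.40 log units; beyond the scatter) leaves compound 2 with the lowest number of the three, with 4-(hydroxymethyl)piperidin-1-yl in place of piperazin-1-yl. No evidence on the cause of either step is available.

From the compounds shown here alone, whether the step comes from losing fluoro or from gaining hydroxymethyl remains open. So does the outcome with a plain hydroxyl, a longer chain, a carboxylic acid or an amine on that carbon.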